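The source may hold more compounds than are shown below. What is called first, only, known or untested is meant among the compounds shown, and "the series" means these compounds.

Measured so far in an in vitro ADME assay on microsomes from liver (Homo sapiens) for pharmacokinetics (on this read-out higher numbers stand for fast clearance and lower numbers for slow clearance), with these values:
compound 1 `Cc1cc(S(=O)(=O)N2C=CNC(=O)[C@H]2CC(=O)N[C@H]2CCNCC2(C)C)c(C)cc1Cl` gives 21 mL.min-1.g-1
compound 2 `Cc1cc(S(=O)(=O)N2C=CNC(=O)[C@H]2CC(=O)N2CC[C@H](N3CCCC3)C2)c(C)cc1Cl` gives 265 mL.min-1.g-1

Going by the values given here, of the two, compound 2 stands highest, and the only measured step (a 13-fold higher number from compound 1 to compound 2 (1.10 log units; beyond the scatter)) is large and beyond the scatter. Still unmeasured is compound 3 (`Cc1cc(S(=O)(=O)N2C=CNC(=O)[C@H]2CC(=O)N2CCC[C@H](N3CCCC3)C2)c(C)cc1Cl`), which differs from compound 2 on a carbonyl carbon (a group of 11 heavy atoms (9 carbon, 2 nitrogen; one five-membered non-aromatic ring with 1 hetero atom, one six-membered non-aromatic ring with 1 hetero atom) in place of a group of 10 heavy atoms (8 carbon, 2 nitrogen; 2 five-membered non-aromatic rings with 1 hetero atom each), on a carbonyl carbon). The measured step changed the group on that same carbonyl carbon, so it shows that this assay can move strongly at this place. Compound 3 keeps one five-membered non-aromatic ring with 1 hetero atom from compound 2 (265 mL.min-1.g-1) and also holds a six-membered non-aromatic ring with 1 hetero atom, as compound 1 does (21 mL.min-1.g-1). A slightly lower number is therefore expected, and the estimated step (a 1.5-fold lower number from compound 2 to compound 3 (0.17 log units; within the scatter)) should stay within the scatter. For compound 3 the expected value is 180 mL.min-1.g-1 (estimated range 70 mL.min-1.g-1 to 400 mL.min-1.g-1).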

Compound 3, intrinsic clearance in microsomes: 235 mL.min-1.g-1
For compound 3 the middle estimate is 1.3-fold (0.12 log units) below the measured one; measured number inside the range.
By their numbers in this assay, from the lowest: compound 1; then compounds 3 and 2 (each within the scatter of the next).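

In this assay, a six-membered non-aromatic ring in the group on the carbonyl carbon does not by itself separate the compounds: the change gives a 1.1-fold lower number from compound 2 to compound 3 (0.05 log units; within the scatter). The high numbers therefore hold across both groups that carry a five-membered non-aromatic ring, and the gap to the group of compound 1 remains large, with an 11-fold higher number from compound 1 to compound 3 (1.05 log units; beyond the scatter). Nothing measured here accounts for this gap.

The compounds shown leave open which feature of the group in compound 1 goes with its low number, as that group differs from the other two in more than one feature. Also open, from the compounds shown here alone, is whether the high numbers persist with a dimethylamino group or a morpholine in place of the five-membered ring of compound 3.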